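A few compounds are considered here, and "the series" means these few. Any claim that something is new, unique, unknown or untested is made for them only; others in the source may bear on it.

Measured compounds:
compound 1, `COc1ccc(-c2cc(=O)c3c(OC)cc(OC)cc3[nH]2)cc1`
compound 2, `COc1ccc(-c2cc(=O)c3c(OC)cc(OC)cc3n2C)cc1`

In a functional assay on SUP-B15 cells (Homo sapiens) for antiproliferative activity, with a stated time of 72 h (on this read-out higher numbers stand for an effect only at larger amounts of compound and lower numbers for an effect already at smaller amounts), compound 1 gives only the assay limit > 62000 nM. Compound 2 gives 28000 nM in this assay, the sole number shown. The other value, that of compound 1, is a limit, (the limit of > 62000 nM in this assay, at which 1 of the 2 values shown sits). Compound 3, `COc1ccc(-c2cc(=O)c3c(OC)cc(OC)cc3n2Cc2ccccc2)cc1`, carries phenyl in place of hydrogen on a saturated chain carbon bound to an aromatic nitrogen. Going by the values given here, the one measured step that bears on this is an at least 2.2-fold lower number from compound 1 to compound 2 (0.34 log units; beyond the scatter), which went toward lower numbers. Extending the methyl to benzyl is expected to give at most a modest further lowering, a 1.9-fold lower number from compound 2 to compound 3 (0.27 log units; within the scatter). Compound 3 is estimated at 15000 nM in this assay, range 5000 nM to 45000 nM.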

Compound 3, half-maximal effective concentration: > 34400 nM
Compound 3: no number, only a limit; the forecaster's own chance of this, stated with the estimate: 15%; middle value at least 2.2-fold (0.36 log units) away from the limit.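

In this assay compound 3 gives only a limit (> 34400 nM). Going by these compounds alone, the change from methyl to benzyl gives an at least 1.2-fold higher number from compound 2 to compound 3 (0.08 log units; that floor lies within the scatter) and so shows no further lowering at this position on the aromatic nitrogen, unlike the first step of hydrogen to methyl. The step between compound 1 and compound 3 cannot be read, since both values are limits.

From the compounds shown here alone, how far compound 3 lies from compound 2 stays open. So does whether an ethyl group or a longer chain ending in an amine on this nitrogen would lower the number.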